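Isopentyl in Place of Methylpyridinyl on the Ring Amine

The compounds below may be only part of what the source reports. "The series", "measured", "known", "first", "only" and "open" are said of these compounds alone.

Compound 1 `CC(C)(C)OC(=O)N1CCC(n2ncc3cc(-c4ccc(S(C)(=O)=O)cc4)ncc32)CC1`: 20 nM
Compound 2 `Cc1ccc(N2CCC(n3ncc4cc(-c5ccc(S(C)(=O)=O)cc5)ncc43)CC2)nc1`: 30 nM

Both compounds were measured in a functional assay on HEK293 cells for agonist activity at Glucose-dependent insulinotropic receptor (Homo sapiens), read by cAMP accumulation, with a stated time of 30 min; on this read-out higher numbers stand for an effect only at larger amounts of compound and lower numbers for an effect already at smaller amounts. Compound 1 gives 20 nM, and compound 2 gives 30 nM, the highest of the two numbers, with compound 1 as its nearest neighbour. The one step shown, a 1.5-fold higher number from compound 1 to compound 2 (0.18 log units; within the scatter), exchanges tert-butoxycarbonyl for 5-methylpyridin-2-yl on the amine nitrogen in a ring and stays within the scatter.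

Compound 3 `CC(C)CCN1CCC(n2ncc3cc(-c4ccc(S(C)(=O)=O)cc4)ncc32)CC1` differs from compound 2 by isopentyl in place of 5-methylpyridin-2-yl on an amine nitrogen in a ring. Among the compounds with values here, the single measured step concerns the same nitrogen, but it trades a carbamate for an aromatic ring, not an aromatic ring for a chain; no measured step places an alkyl chain at this site. Because that one step, a 1.5-fold higher number from compound 1 to compound 2 (0.18 log units; within the scatter), barely moved the number, only a modest shift is expected for compound 3, estimated as a 2.0-fold higher number from compound 2 to compound 3 (0.30 log units; within the scatter). Compound 3 is therefore estimated at 60 nM, within a range from 15 nM to 300 nM.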

Compound 3, half-maximal effective concentration: 220 nM
Estimate against measurement, compound 3: 3.7-fold (0.56 log units) below; measured number inside the range.
By their numbers in this assay, from the lowest: compounds 1 and 2 (each within the scatter of the next); then compound 3.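

The amine nitrogen in the ring does not accept every group equally: tert-butoxycarbonyl and 5-methylpyridin-2-yl stood within the scatter of each other in this assay, but isopentyl gives a 7.3-fold higher number from compound 2 to compound 3 (0.87 log units; beyond the scatter) and an 11-fold higher number from compound 1 to compound 3 (1.04 log units; beyond the scatter), so an effect there now takes larger amounts of compound. In the step from the pyridine, the six-membered aromatic ring and its hydrogen-bond acceptor leave, and a chain with no ring and no acceptor enters. Nothing measured here explains this loss.

The compounds shown leave open whether the ring, the acceptor or the shape of the chain accounts for the step. A phenyl ring on this nitrogen, or a chain carrying an ether oxygen or an amine, would help to tell these apart.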